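Swapping the Five-Membered Ring on a Shared Core

The compounds below may be only part of what the source reports. "The series", "measured", "known", "first", "only" and "open" are said of these compounds alone.

Compound 3 `C/C(=C1/OC(=O)NC1=O)C(c1ccc(-c2ccc3cccc(F)c3c2)[nH]c1=O)C(C)C` gives 17 nM in an assay on membranes from Chem-1 cells for displacement of a labelled ligand from prostaglandin E2 receptor EP3 subtype (Homo sapiens), read by scintillation counting, with a stated time of 2 h (on this read-out higher numbers stand for weaker inhibition and lower numbers for stronger inhibition), level with compound 1 `CC(C)C(CC1C(=O)NC(=O)N1C)c1ccc(-c2ccc3cccc(F)c3c2)[nH]c1=O` at 17 nM, the two together the lowest of the three numbers; compound 2 `CC(C)C(c1ccc(-c2ccc3cccc(F)c3c2)[nH]c1=O)C1NC(=O)NC1=O` sits higher at 50 nM. Compound 4 `CC(C)C(c1ccc(-c2ccc3cccc(F)c3c2)[nH]c1=O)C1C(=O)NC(=O)N1C` carries a group of 8 heavy atoms (4 carbon, 2 nitrogen, 2 oxygen; one five-membered non-aromatic ring with 2 hetero atoms) in place of a group of 9 heavy atoms (5 carbon, 1 nitrogen, 3 oxygen; one five-membered non-aromatic ring with 2 hetero atoms), on a saturated chain carbon bound to an aromatic carbon and a saturated chain carbon. Going by the values given here, two measured steps bear on this change: no change at the digits printed from compound 1 to compound 3 (within the scatter), and a 2.9-fold higher number from compound 1 to compound 2 (0.47 log units; beyond the scatter), where compound 2 bears its 2,5-dioxoimidazolidin-4-yl on the same saturated chain carbon as compound 4 but without the methyl of the 3-methyl-2,5-dioxoimidazolidin-4-yl group. A modest rise in this assay is therefore expected for compound 4, a 1.8-fold higher number from compound 3 to compound 4 (0.25 log units; within the scatter). Compound 4 is estimated at 30 nM, with a range from 12 nM to 80 nM.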

Compound 4, inhibition constant: 46 nM
Beside the measured number, compound 4's estimate is 1.5-fold (0.19 log units) below it; the measured number falls inside the stated range.
By their numbers in this assay, from the lowest: compounds 1 and 3 (each within the scatter of the next); then compounds 4 and 2 (each within the scatter of the next).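

In this assay, the methyl on the amide-type nitrogen in the ring proves to lie within the scatter (a 1.1-fold lower number from compound 2 to compound 4 (0.04 log units; within the scatter)). By contrast, 3-methyl-2,5-dioxoimidazolidin-4-yl in place of (3-methyl-2,5-dioxoimidazolidin-4-yl)methyl gives a step beyond the scatter (a 2.7-fold higher number from compound 1 to compound 4 (0.43 log units; beyond the scatter)), and the same group also separates from the group carried by compound 3 (a 2.7-fold higher number from compound 3 to compound 4 (0.43 log units; beyond the scatter)). Nothing measured here explains these steps. Still open, going by these compounds, is whether a longer chain bearing the 3-methyl-2,5-dioxoimidazolidin-4-yl group, or a carboxylic acid in its place, would give a number level with compound 1.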